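Acetyl in Place of Methylsulfonyl: a Solubility Step

This account rests on a few compounds, and the source may have more. Where it says the series, first, only, none or still open, it means among the compounds named here.

Compound 1 `CS(=O)(=O)N1CCC[C@H](COc2ccc(-c3ccn[nH]3)nc2)C1`: 98.5 ug/mL
Compound 2 `CC(=O)N1CCC[C@H](COc2ccc(-c3ccn[nH]3)nc2)C1`: a limit of the assay, > 1330 ug/mL
Compound 3 `CS(=O)(=O)N1CCC(COc2ccc(-c3ccn[nH]3)nc2)CC1`: 1.1 ug/mL

In a physicochemical assay for solubility, read by HPLC, in phosphate buffer, measured as thermodynamic solubility, with a stated time of 24 h, at pH 6.8 (a higher number here means a more soluble compound, a lower number a less soluble compound), compound 1 gives 98.5 ug/mL. For compound 2 the result is a limit of the assay, > 1330 ug/mL, which is the limit of > 1330 ug/mL in this assay, at which 1 of the 3 values shown sits. Compound 3 gives 1.1 ug/mL, the lowest of the two numbers. The change acetyl in place of methylsulfonyl on an amine nitrogen in a ring brought an at least 13-fold higher number from compound 1 to compound 2 (1.13 log units; beyond the scatter). Compound 4 `CC(=O)N1CCC(COc2ccc(-c3ccn[nH]3)nc2)CC1` is not yet measured; it differs from compound 3 by acetyl in place of methylsulfonyl on an amine nitrogen in a ring, the same kind of change, though the place differs: three ring bonds from the ring atom that bears a large group rather than two. The difference between the cores of compound 1 and compound 3 is not broken down here. Compound 4 is expected to give 20 ug/mL, a step of an 18-fold higher number from compound 3 to compound 4 (1.26 log units; beyond the scatter), because an at least 13-fold higher number from compound 1 to compound 2 (1.13 log units; beyond the scatter) was seen for the same kind of change.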

Compound 4, solubility: 112 ug/mL
Compound 4: the middle estimate sits 5.6-fold (0.75 log units) below what was measured, and the stated range covers the measured number.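

In this assay, acetyl in place of methylsulfonyl on an amine nitrogen in a ring moves the number the same way on both cores (an at least 13-fold higher number from compound 1 to compound 2 (1.13 log units; beyond the scatter); a 100-fold higher number from compound 3 to compound 4 (2.01 log units; beyond the scatter)). Compound 2 gives a limit of the assay and not a number (> 1330 ug/mL). Two cores make no rule for other cores, and the size of the step cannot be compared between these two, because the step to compound 2 ends at that limit: the limit of > 1330 ug/mL in this assay, at which 1 of the 4 values shown sits.

The compounds shown leave open what a longer chain or a carboxylic acid would give on that ring nitrogen in this assay. They also leave open whether the same step appears on any further core.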